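The source may hold more compounds than are shown below. What is called first, only, known or untested is meant among the compounds shown, and "the series" means these compounds.

In a functional assay on DU-145 cells (Homo sapiens) for antiproliferative activity, with stated times of 2 days and 4 days (on this read-out lower numbers stand for stronger inhibition and higher numbers for weaker inhibition), compound 1 `COc1ccc(O)c(C(=O)/C=C/c2ccccc2OC)c1` gives > 10000 nM as its reading, and this is a limit of the assay and not a number. Its exact place on the scale is therefore unknown. Compound 2 `O=C(/C=C/c1ccccc1O)c1cc(Cl)ccc1O` gives 4500 nM as a true number in the same test. Compound 3 `COc1ccccc1/C=C/C(=O)c1cc(Br)ccc1O` keeps the core of compound 1 and swaps one group (bromo in place of methoxy on an aromatic carbon) on an aromatic carbon para to a hydroxy group, with bromo in place of methoxy. Among the compounds with values here, no measured pair here isolates a single change, so the size of this step has little direct support. A modest gain in strength is expected in this assay because compound 2 gives 4500 nM as a real reading, which shows that a measurable result is possible in this small set. A reading that again fails to give a number would still be no surprise. The expected move is an at least 1.6-fold lower number from compound 1 to compound 3 (0.22 log units; that floor lies within the scatter) and it remains a rough estimate. For compound 3 the estimated value is 6000 nM with an expected range from 2500 nM to 15000 nM as a plausible span.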

Compound 3, half-maximal inhibitory concentration: 6130 nM
Beside the measured number, compound 3's estimate is 1.0-fold (0.01 log units) below it; low and high end bracket the measured number.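

In this assay, within the data shown here, the swap of methoxy for bromo, on an aromatic carbon para to a hydroxy group, gives an at least 1.6-fold lower number from compound 1 to compound 3 (0.21 log units; that floor lies within the scatter) and is the first single change in this set that can be followed as a step. Compound 1 gives > 10000 nM as its reading, which is a limit of the assay and not a number. The step is therefore only a floor, its true size could be larger, and that floor lies within the usual scatter, so the change at this position yields a real reading but no exact measure of the gain: the limit of > 10000 nM in this assay, at which 1 of the 3 values shown sits.

The compounds shown leave open how other groups on this same carbon, such as an amine or a carboxylic acid, would read, and so whether bromo is a particularly good replacement for methoxy or merely one of several that work. Among these compounds, they also leave open whether the same swap would lower the number to a similar degree on a different core, as this single pair offers only one example of the change.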